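A chlorine leaves, a carbon-bearing group enters

This account rests on a few compounds, and the source may have more. Where it says the series, first, only, none or still open, it means among the compounds named here.

In a functional assay on HT-29 cells (Homo sapiens) for cytotoxicity, read by sulforhodamine B assay (a higher number here means a weaker inhibitor of growth, a lower number a stronger inhibitor of growth), compound 2 `CC1=CC[C@@H]([C@@](C)(O)CCCC(C)(C)NC(=S)N/N=C\c2ccc(Cl)cc2)CC1` gives 7350 nM, the lowest of the two numbers shown, while compound 1 `CC1=CC[C@@H]([C@@](C)(O)CCCC(C)(C)NC(=S)N/N=C\c2ccccc2)CC1` gives 9960 nM, within the scatter of it, as the step of a 1.4-fold lower number from compound 1 to compound 2 (0.13 log units; within the scatter) confirms. Compound 3 `CC1=CC[C@@H]([C@@](C)(O)CCCC(C)(C)NC(=S)N/N=C(/C)c2ccccc2)CC1` differs from compound 2 by a group of 9 heavy atoms (8 carbon, 1 nitrogen; one six-membered aromatic ring of carbon only) in place of a group of 9 heavy atoms (7 carbon, 1 nitrogen, 1 chlorine; one six-membered aromatic ring of carbon only), on an amide-type nitrogen. Going by the values given here, the only measured step bearing on this is a 1.4-fold lower number from compound 1 to compound 2 (0.13 log units; within the scatter), which covers the departing chlorine alone and was within the scatter; nothing measured covers the entering group. A change no larger than the scatter is therefore expected, estimated as a 1.4-fold higher number from compound 2 to compound 3 (0.13 log units; within the scatter). Compound 3 is expected to give 10000 nM, within a range from 4000 nM to 25000 nM.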

Compound 3, concentration for 50% growth inhibition: 28400 nM
Compound 3: middle estimate off by 2.8-fold (0.45 log units), on the low side, and the stated range ends below it.
By their numbers in this assay, from the lowest: compounds 2 and 1 (each within the scatter of the next); then compound 3.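

In this assay, going by these compounds alone, the group of 9 heavy atoms (8 carbon, 1 nitrogen) on the amide-type nitrogen gives the first steps beyond the scatter, with a 3.9-fold higher number from compound 2 to compound 3 (0.59 log units; beyond the scatter) and a 2.9-fold higher number from compound 1 to compound 3 (0.46 log units; beyond the scatter) both moving toward weaker growth inhibition. This position therefore responds to a change that the chloro step, at a 1.4-fold lower number from compound 1 to compound 2 (0.13 log units; within the scatter), did not show. Nothing available explains this loss. The compounds shown leave open whether an ethyl group or an amine within the entering group would raise the number further or bring it back.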